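This account rests on a few compounds, and the source may have more. Where it says the series, first, only, none or still open, it means among the compounds named here.

Compound 3 `O=C(CCCc1ccccc1)NNc1c(Cl)cncc1Cl` gives 770 nM in a functional assay on HEK293 cells for antagonist activity at P2X purinoceptor 7 (Homo sapiens), read by fluorescence, with a stated time of 2 h (on this read-out lower numbers stand for stronger inhibition and higher numbers for weaker inhibition), the lowest of the three numbers shown, though its gaps to compound 1 `O=C(CCc1ccc(Cl)cc1)NNc1c(Cl)cncc1Cl`, at 1100 nM, and to compound 2 `Cc1ccc(CCC(=O)NNc2c(Cl)cncc2Cl)cc1`, at 1400 nM, both lie within the scatter. Compound 4 `O=C(CCCCc1ccccc1)NNc1c(Cl)cncc1Cl` differs from compound 3 by benzyl in place of phenyl on a saturated chain carbon, three bonds along the chain from a carbonyl carbon. The closest precedents are the steps of a 1.4-fold lower number from compound 1 to compound 3 (0.15 log units; within the scatter) and a 1.8-fold lower number from compound 2 to compound 3 (0.26 log units; within the scatter), in each of which a benzyl replaced a substituted phenyl on the chain and the number hardly moved. On that basis the step of a 1.0-fold lower number from compound 3 to compound 4 (0.01 log units; within the scatter) is expected to stay within the scatter, with no clear direction. Compound 4 is therefore estimated at 750 nM, with a range from 300 nM to 1900 nM.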

Compound 4, half-maximal inhibitory concentration: 1200 nM
Estimate against measurement, compound 4: 1.6-fold (0.20 log units) below, within the range that was stated.
By their numbers in this assay, from the lowest: compounds 3, 1, 4 and 2 (each within the scatter of the next).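

Replacing phenyl with benzyl, three bonds along the chain from a carbonyl carbon, gives a 1.6-fold higher number from compound 3 to compound 4 (0.19 log units; within the scatter) in this assay. Unlike the earlier steps, this one leaves the aromatic ring unsubstituted and only adds to the chain, and that addition stays within the scatter. The position therefore accepts this extra carbon without a readable change in the number. Still open, on these data alone, is whether a longer chain would do the same, or whether an amine or a carboxylic acid on the ring of compound 4 would shift the number. Nothing available explains why this change leaves the number within the scatter.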